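A few compounds are considered here, and "the series" means these few. Any claim that something is new, unique, unknown or untested is made for them only; others in the source may bear on it.

Of the compounds shown here, two that share the same core have been measured in a functional assay with Alpha-1B adrenergic receptor (Homo sapiens) as the target, read by calcium flux; on this read-out higher numbers stand for larger maximal responses and lower numbers for smaller maximal responses. Compound 1 `Cn1cccc1-c1ccccc1NCC1=NCCN1` gives 0% in this assay, meaning no maximal response above the control is seen. Compound 2 `Cc1n[nH]c(-c2ccccc2NCC2=NCCN2)n1` gives 0% in this assay. The step of no change at the digits printed from compound 1 to compound 2 (within the scatter) exchanges one five-membered aromatic ring for another on an aromatic carbon and leaves the read-out where it was. Compound 2 therefore stands level with compound 1 at the digits shown, and neither compound produces any maximal response.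

Compound 3 `Cn1cc(-c2ccccc2NCC2=NCCN2)cn1` has not been measured yet. It differs from compound 2 by 1-methyl-1H-pyrazol-4-yl in place of 3-methyl-1H-1,2,4-triazol-5-yl on an aromatic carbon. Going by the values given here, the only measured step that bears on this change is the swap of one five-membered aromatic ring for another on the same kind of aromatic carbon, which brought no change within the scatter. Because that swap gave no change at the digits printed from compound 1 to compound 2 (within the scatter), compound 3 is expected to show no change at the digits printed from compound 2 to compound 3 (within the scatter), with no movement beyond the scatter in either direction. For compound 3 the estimated maximal response is 0%, with a range from -5% to 10%.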

Compound 3, largest response reached (reported as maximal response), in percent of the reference or control that the assay uses: 0%
Compound 3: the middle estimate sits on the measured number at the digits printed, and the stated range covers the measured number.
By their numbers in this assay, from the lowest: compounds 1, 2 and 3 (each within the scatter of the next).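

In this assay, the 1-methyl-1H-pyrazol-4-yl group leaves the read-out where it was, with no change at the digits printed from compound 2 to compound 3 (within the scatter) and no change at the digits printed from compound 1 to compound 3 (within the scatter) as the two steps that show this. Three different five-membered aromatic rings have now been tried on this aromatic carbon of the six-membered ring, and none of them produces a maximal response, even though this last change goes from a ring with 3 hetero atoms and 1 hydrogen-bond donor to one with 2 hetero atoms and 0 hydrogen-bond donors. No other measurement is at hand that would explain why the response stays flat across these rings.

With all three compounds at the same value, this series cannot yet show which features of the group at this position matter for the response, since no group has moved it. As far as these compounds go, it remains open whether a different kind of group in the same place, such as an amine, a carboxylic acid, a longer chain or a six-membered pyridine ring, would give any maximal response at all.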